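Trifluoromethyl in place of fluoro on compound 3

A few compounds are considered here, and "the series" means these few. Any claim that something is new, unique, unknown or untested is made for them only; others in the source may bear on it.

In an ADME assay on MT4 cells (Homo sapiens) for cytotoxicity, read by MTT assay, with a stated time of 4 days (a higher number here means that more compound is tolerated, a lower number that less compound is tolerated), compound 3 (`Nc1ccc2oc(-c3ccc(F)cc3)cc(=O)c2c1`) gives 264000 nM and stands within the scatter of the other two measured compounds. Compound 1 (`CC(=O)Nc1ccc2oc(-c3ccc(F)cc3)cc(=O)c2c1`) gives 203000 nM and compound 2 (`CC(=O)Nc1ccc2oc(-c3ccc(C(F)(F)F)cc3)cc(=O)c2c1`) gives 330000 nM on the same scale. Compound 4 (`Nc1ccc2oc(-c3ccc(C(F)(F)F)cc3)cc(=O)c2c1`) has trifluoromethyl in place of fluoro on an aromatic carbon. The same exchange has been measured once, as a 1.6-fold higher number from compound 1 to compound 2 (0.21 log units; within the scatter) and removing acetyl from the nitrogen gave only a 1.3-fold higher number from compound 1 to compound 3 (0.11 log units; within the scatter) so no step beyond the scatter is expected in this assay here. The estimated step is a 1.4-fold higher number from compound 3 to compound 4 (0.16 log units; within the scatter) and it points the same way as that earlier exchange. For compound 4 the expected value is 380000 nM with an estimated range from 210000 nM to 650000 nM as its likely span.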

Compound 4, half-maximal cytotoxic concentration: 273000 nM
Estimate against measurement, compound 4: 1.4-fold (0.14 log units) above; the range from low to high includes it.
By their numbers in this assay, from the lowest: compounds 1, 3, 4 and 2 (each within the scatter of the next).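

With compound 4, both changes have now been read a second time in this assay: trifluoromethyl in place of fluoro on the core without acetyl (a 1.0-fold higher number from compound 3 to compound 4 (0.01 log units; within the scatter)), and hydrogen in place of acetyl on the nitrogen with trifluoromethyl present (a 1.2-fold lower number from compound 2 to compound 4 (0.08 log units; within the scatter)). The trifluoromethyl exchange gives no step beyond the scatter whether the nitrogen carries acetyl or hydrogen: the same change on two cores in this assay, a 1.6-fold higher number (0.21 log units; within the scatter) from compound 1 to compound 2 and a 1.0-fold higher number (0.01 log units; within the scatter) from compound 3 to compound 4, 1.6-fold (0.20 log units) apart, within the scatter of two such steps. Among these compounds, likewise, losing the acetyl gives no such step with either fluoro or trifluoromethyl on the ring: the same change on two cores in this assay, a 1.3-fold higher number (0.11 log units; within the scatter) from compound 1 to compound 3 and a 1.2-fold lower number (0.08 log units; within the scatter) from compound 2 to compound 4, 1.6-fold (0.20 log units) apart, within the scatter of two such steps.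

Still open, from the compounds shown here alone, is whether any group at these two places moves the number beyond the scatter. A carboxylic acid in place of trifluoromethyl, or a longer chain in place of acetyl on the nitrogen, would test this.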